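From 4-Fluorobenzyl to 2-Bromobenzyl: A Step Toward the Limit?

This account rests on a few compounds, and the source may have more. Where it says the series, first, only, none or still open, it means among the compounds named here.

Going by the values given here, in a functional assay on HOS cells (Homo sapiens) for antiproliferative activity, with a stated time of 72 h (a lower number here means a stronger inhibitor, a higher number a weaker inhibitor), compound 2 (`OC[C@H]1O[C@@H](n2cnc3c(NCc4ccc(F)cc4)ncnc32)[C@H](O)[C@@H]1O`) gives 13200 nM, the only actual number among the three compounds measured. Compound 1 (`OC[C@H]1O[C@@H](n2cnc3c(NCc4ccccc4F)ncnc32)[C@H](O)[C@@H]1O`) reads > 166000 nM, which is a limit of the assay. Compound 3 (`OC[C@H]1O[C@@H](n2cnc3c(NCc4ccc(Cl)cc4)ncnc32)[C@H](O)[C@@H]1O`) reads > 166000 nM, which is also a limit.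

Compound 4 (`OC[C@H]1O[C@@H](n2cnc3c(NCc4ccccc4Br)ncnc32)[C@H](O)[C@@H]1O`) departs from compound 2 by one change: 2-bromophenyl in place of 4-fluorophenyl on a saturated chain carbon bound to a nitrogen on an aromatic ring. Here 2-bromophenyl stands in place of 4-fluorophenyl on a saturated chain carbon bound to a nitrogen on an aromatic ring.

Among the compounds with values here, two measured steps bear on this change. Exchanging 2-fluorophenyl for 4-fluorophenyl gave an at least 12-fold lower number from compound 1 to compound 2 (1.09 log units; beyond the scatter), and chloro in place of fluoro gave an at least 12-fold higher number from compound 2 to compound 3 (1.09 log units; beyond the scatter). Both steps are large, and the remaining compounds sit at the limit of > 166000 nM in this assay, at which 2 of the 3 values shown sit. Compound 4 gives up the 4-fluorophenyl group that only compound 2 carries, so a large step toward a higher number is expected. The expected change is a 6.8-fold higher number from compound 2 to compound 4 (0.83 log units; beyond the scatter). For compound 4 the estimate is 90000 nM, with an expected range of 18000 nM to 250000 nM.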

Compound 4, half-maximal inhibitory concentration: > 166000 nM
Compound 4 ended at the assay's limit (the forecaster's own chance of this, stated with the estimate: 60%); middle value at least 1.8-fold (0.26 log units) from the limit.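

In this assay, 2-bromophenyl in place of 4-fluorophenyl gives an at least 12-fold higher number from compound 2 to compound 4 (1.09 log units; beyond the scatter), so a third replacement of the 4-fluorophenyl group on this saturated chain carbon has lost the measurable value of compound 2. Compound 4 reads > 166000 nM, which is a limit of the assay. Bromo now joins 2-fluorophenyl and 4-chlorophenyl in leaving no number, and the steps among compound 1, compound 3 and compound 4 cannot be read, so only the 4-fluorophenyl group of compound 2 stands apart: the limit of > 166000 nM in this assay, at which 3 of the 4 values shown sit.

The compounds shown leave open how far these three lie beyond that limit and whether they differ from one another at all. They also leave open whether unsubstituted phenyl, 4-methoxyphenyl or 3-fluorophenyl at this place would give a number.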